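From methyl to difluoromethoxy: estimating clearance for compound 3

This account rests on a few compounds, and the source may have more. Where it says the series, first, only, none or still open, it means among the compounds named here.

Compound 1 `Cc1cccc([C@H](C)NC(=O)Cn2nnc3ccccc3c2=O)c1`: 11 mL/min/kg
Compound 2 `Cc1ccc([C@H](C)NC(=O)Cn2nnc3ccccc3c2=O)cc1`: < 9.9 mL/min/kg

Both compounds were tested in an ADME assay on microsomes from liver (Homo sapiens) for metabolic stability; on this read-out higher numbers stand for fast clearance and lower numbers for slow clearance. The reading for compound 2 is only a limit of the assay, not a number: < 9.9 mL/min/kg. This is the limit of < 9.9 mL/min/kg in this assay, at which 1 of the 2 values shown sits. Compound 3 `C[C@H](NC(=O)Cn1nnc2ccccc2c1=O)c1ccc(OC(F)F)cc1` has not yet been measured. It differs from compound 2 by difluoromethoxy in place of methyl on an aromatic carbon. Going by the values given here, the only measured step is an at least 1.1-fold lower number from compound 1 to compound 2 (0.04 log units; that floor lies within the scatter). That step puts 4-methylphenyl in place of 3-methylphenyl and does not replace the methyl with another group, so it offers only a loose guide. No step beyond the scatter is therefore expected in this assay, and no direction can be favoured with confidence. For compound 3 the expected value is 11 mL/min/kg, within an estimated range of 7 mL/min/kg to 22 mL/min/kg. The estimate amounts to an expected step of an at least 1.1-fold higher number from compound 2 to compound 3 (0.04 log units; that floor lies within the scatter).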

Compound 3, clearance: < 9.9 mL/min/kg
Compound 3: no number, only a limit (the forecaster's own chance of this, stated with the estimate: 40%); middle value at least 1.1-fold (0.04 log units) from the limit.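

Compound 2 and compound 3 each give only a limit of the assay in this assay, not a number, so no step between them can be read: the limit of < 9.9 mL/min/kg in this assay, at which 2 of the 3 values shown sit.

The compounds shown leave open whether difluoromethoxy in place of methyl on an aromatic carbon changes clearance at all, and in which direction.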